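This account rests on a few compounds, and the source may have more. Where it says the series, first, only, none or still open, it means among the compounds named here.

Measured compounds:

Compound 1, `Cc1ccc(C)c(-c2nc(CN3CCC(C(=O)NCCCN4C[C@H](C)C[C@H](C)C4)CC3)c(C)o2)c1`: in an ADME assay on microsomes from liver (Rattus norvegicus) for metabolic stability, read by LC-MS, using NADPH, at 37 degrees C (on this read-out lower numbers stand for a shorter-lived compound and higher numbers for a longer-lived compound), compound 1 gives 0.5 h.
Compound 2, `Cc1ccccc1-c1nc(CN2CCC(C(=O)NCCCN3CCC(C(C)C)CC3)CC2)c(C)o1`: in this assay compound 2 gives 0.147 h.
Compound 3, `Cc1cccc(Cl)c1-c1nc(CN2CCC(C(=O)NCCCN3CCCC(C)C3)CC2)c(C)o1`: in this assay compound 3 gives 0.09 h.

Compound 2 stands second highest among the three numbers. Its nearest neighbour is compound 3, whose value lies within the usual scatter of its own, so no order can be read between those two. Compound 1 stands furthest off, with a number beyond the scatter above that of compound 2.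

Compound 4, `CCCN(CCC)CCNC(=O)C1CCN(Cc2nc(-c3ccccc3C)oc2C)CC1`, has not yet been run in this assay. It differs from compound 2 in one place: dipropylamino in place of (4-isopropylpiperidin-1-yl)methyl on a saturated chain carbon, two bonds along the chain from an amide-type nitrogen. Within the data shown here, no step between two measured compounds mirrors this change, so nothing within the set shows how such a swap moves the half-life. With that gap, the expectation rests on compound 2 alone, and the step is expected to fall within the scatter, with no direction claimed: a 1.2-fold higher number from compound 2 to compound 4 (0.06 log units; within the scatter).

On that basis compound 4 is estimated at 0.17 h, with a range from 0.07 h to 0.45 h.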

Compound 4, half-life: > 0.5 h
Compound 4 ended at the assay's limit; the forecaster's own chance of this, stated with the estimate: 5%; middle value at least 2.9-fold (0.46 log units) away from the limit.
By their numbers in this assay, from the lowest: compounds 3 and 2 (each within the scatter of the next); then compound 1.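

Among these compounds, this is the first change in one place that can be read at this position, and it shows that the half-life responds to what sits there: dipropylamino in place of (4-isopropylpiperidin-1-yl)methyl, on a saturated chain carbon, two bonds along the chain from an amide-type nitrogen, gives an at least 3.4-fold higher number from compound 2 to compound 4 (0.53 log units; beyond the scatter). In this assay compound 4 gives > 0.5 h, which is a limit of the assay and not a number. The step therefore fixes a direction and a minimum size beyond the scatter, but not how far the change really reaches: the limit of > 0.5 h in this assay, at which 1 of the 4 values shown sits.

A single pair cannot tell whether the step follows from the open chain replacing the ring or from the smaller group as a whole, and a plain piperidin-1-yl or a diethylamino group at the same place would help to separate the two. As far as these compounds go, it also remains open whether the same swap moves the half-life in the same way on the core of compound 1 or of compound 3.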